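Nitrofuran imine in the aminothiophene diester series

The source may report more compounds than this note shows. Statements on the series, on what has been measured and on what is new or still open speak of the compounds shown alone.

For the measured compounds named here, compound 1 `CCOC(=O)c1c(N)sc(/N=C/c2ccc(OC)cc2)c1C(=O)OCC` carries the 4-methoxyphenyl imine and is the weakest of the three measured members: in a functional assay on T47D cells (Homo sapiens) for inhibition, read by MTT assay, with a stated time of 48 h (a higher number here means a weaker inhibitor, a lower number a stronger inhibitor), compound 1 gives 31900 nM. Compound 2 `CCOC(=O)c1c(N)sc(/N=C/c2ccco2)c1C(=O)OCC` gives 14900 nM, and compound 3 `CCOC(=O)c1c(N)sc(/N=C/c2ccc([N+](=O)[O-])cc2)c1C(=O)OCC` gives 2300 nM. Compound 4 `CCOC(=O)c1c(N)sc(/N=C/c2ccc([N+](=O)[O-])o2)c1C(=O)OCC` is not yet measured. The change from compound 1 is 5-nitrofuran-2-yl in place of 4-methoxyphenyl on a carbon with a double bond to nitrogen. Going by the values given here, two measured steps bear on it: a 2.1-fold lower number from compound 1 to compound 2 (0.33 log units; beyond the scatter), and a 14-fold lower number from compound 1 to compound 3 (1.14 log units; beyond the scatter). Both parts of the change point the same way, so a large step downward is expected for compound 4, roughly the two steps taken together, giving a 21-fold lower number from compound 1 to compound 4 (1.33 log units; beyond the scatter). Compound 4 is therefore estimated at 1500 nM, with a range from 400 nM to 6000 nM.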

Compound 4, half-maximal inhibitory concentration: 16000 nM
The estimate for compound 4 lay 11-fold (1.03 log units) below the measured number; measured number above the stated range.
By their numbers in this assay, from the lowest: compound 3; then compounds 2, 4 and 1 (each within the scatter of the next, the first and the last beyond it).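

Here the nitro group's effect depends on the ring that carries it: 5-nitrofuran-2-yl in place of 4-methoxyphenyl gives only a 2.0-fold lower number from compound 1 to compound 4 (0.30 log units; within the scatter), and in place of 4-nitrophenyl it gives a 7.0-fold higher number from compound 3 to compound 4 (0.84 log units; beyond the scatter). Nitro in place of hydrogen on the furan gives a 1.1-fold higher number from compound 2 to compound 4 (0.03 log units; within the scatter), so the two earlier steps do not add up on this ring. No measurement available explains this dependence on the ring. Still open, going by these compounds, is whether a nitrile or a carboxylic acid in place of nitro would separate the phenyl and furan imines in the same way.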